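The compounds below may be only part of what the source reports. "The series", "measured", "known", "first", "only" and "open" are said of these compounds alone.

Measured compounds:
compound 1, `CN1C(=O)C(CCNc2ccccc2)COC12C=CC(=O)C=C2`: in an assay on isolated protein for inhibition of N-lysine methyltransferase SMYD2 (Homo sapiens), read by filter binding, with a stated time of 1 h (a lower number here means a stronger inhibitor, a higher number a weaker inhibitor), compound 1 gives > 20000 nM, which is a limit of the assay.
compound 2, `CN1C(=O)C(CCNc2ccc(C(=O)c3ccccc3)cc2)COC12C=CC(=O)C=C2`: in this assay compound 2 gives > 20000 nM, which is likewise a limit.

Compound 1 stands only at a limit in this assay, with no number of its own. Among the measured compounds shown here, the one further value shown, for compound 2, is a limit as well. Both sit at the limit of > 20000 nM in this assay, at which 2 of the 2 values shown sit. The step from compound 1 to compound 2, a step that the two limits leave unreadable from compound 1 to compound 2, puts benzoyl in place of hydrogen on an aromatic carbon, and its size cannot be read from two limits.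

Compound 3, `CN1C(=O)C(CCO[Si](C)(C)C(C)(C)C)COC12C=CC(=O)C=C2`, differs from compound 1 by a group of 8 heavy atoms (6 carbon, 1 oxygen, 1 silicon; no ring) in place of a group of 7 heavy atoms (6 carbon, 1 nitrogen; one six-membered aromatic ring of carbon only), on a saturated chain carbon, two bonds along the chain from a saturated ring carbon. For the measured compounds named here, no measured step yields a readable size, so nothing in the data points to a change in either direction for this exchange; the only evidence is the limit of > 20000 nM in this assay, at which 2 of the 2 values shown sit, where both measured values sit. Compound 3 is therefore expected to stay at the limit too, with a step that the limit leaves unreadable from compound 1 to compound 3 expected to be no readable step beyond the scatter. The value of compound 3 in this assay is estimated at 40000 nM, within 10000 nM to 200000 nM.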

Compound 3, half-maximal inhibitory concentration: > 30000 nM
Compound 3 ended at the assay's limit; the forecaster's own chance of this, stated with the estimate: 85%; the middle value does not contradict the limit.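

In this assay compound 3 gives > 30000 nM as a limit of the assay. Among the compounds shown here, compound 1 and compound 3 both stand only at limits, so no step between them can be read. The compounds shown leave open whether in this assay any group on the shared core gives a readable value at all.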